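The source may hold more compounds than are shown below. What is called first, only, known or untested is meant among the compounds shown, and "the series" means these compounds.

Measured so far in an assay on isolated protein for binding affinity to 5-hydroxytryptamine receptor 7 (Homo sapiens); on this read-out higher numbers stand for weaker inhibition and lower numbers for stronger inhibition:
compound 1, `O=C1c2ccccc2CCCN1CCN1CCC(Oc2ccc(F)cc2)CC1`, 4.47 nM;
compound 2, `O=C(c1ccc(F)cc1)C1CCN(CCN2CCCc3ccccc3C2=O)CC1`, 1.66 nM;
compound 3, `O=C1c2ccccc2CCCN1CCN1CCC(c2c[nH]c3ccccc23)CC1`, 0.407 nM.

Compound 3 gives the lowest number of the three in this assay. Its lead over compound 2 is a 4.1-fold lower number from compound 2 to compound 3 (0.61 log units; beyond the scatter), and over compound 1 it is an 11-fold lower number from compound 1 to compound 3 (1.04 log units; beyond the scatter); both of those steps lie beyond the scatter, so compound 3 is the strongest binder of the three measured.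

Compound 4, `O=C1c2ccccc2CCCN1CCN1CCC(n2nnc3ccccc32)CC1`, is not yet measured. It differs from compound 3 in one place: a group of 9 heavy atoms (6 carbon, 3 nitrogen; one five-membered aromatic ring with 3 hetero atoms, one six-membered aromatic ring of carbon only) in place of a group of 9 heavy atoms (8 carbon, 1 nitrogen; one five-membered aromatic ring with 1 hetero atom, one six-membered aromatic ring of carbon only), on a saturated ring carbon. Going by the values given here, none of the measured steps covers this change. The two steps that end at compound 3, an 11-fold lower number from compound 1 to compound 3 (1.04 log units; beyond the scatter) and a 4.1-fold lower number from compound 2 to compound 3 (0.61 log units; beyond the scatter), both reward the entry of the 1H-indol-3-yl group that now leaves; they say nothing about the group that enters. Given that, the number for compound 4 is expected to move up from compound 3 by a 7.4-fold higher number from compound 3 to compound 4 (0.87 log units; beyond the scatter) in this assay, a modest step beyond the scatter. Compound 4 is thus estimated at 3 nM, with a likely range from 0.8 nM to 12 nM.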

Compound 4, inhibition constant: 14.1 nM
Estimate against measurement, compound 4: 4.7-fold (0.67 log units) below; the whole stated range lies below it.
By their numbers in this assay, from the lowest: compound 3; then compound 2; then compound 1; then compound 4.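

In this assay, this position on the saturated ring carbon separates two fused aromatic groups of equal heavy-atom count: a 35-fold higher number from compound 3 to compound 4 (1.54 log units; beyond the scatter) when the triply nitrogen-bearing group replaces 1H-indol-3-yl, so a matching count and ring pattern do not preserve binding. The same group also falls behind both single-ring substituents, with an 8.5-fold higher number from compound 2 to compound 4 (0.93 log units; beyond the scatter) against (4-fluorophenyl)carbonyl and a 3.2-fold higher number from compound 1 to compound 4 (0.50 log units; beyond the scatter) against 4-fluorophenoxy, which makes compound 4 the weakest binder of the four. Nothing available accounts for this loss.

The compounds shown leave open whether the loss follows the missing hydrogen-bond donor, the added ring nitrogens or the attachment through a ring nitrogen. A 1H-indol-1-yl group, with the carbon and nitrogen count of the indole but attached through nitrogen, would help separate these.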